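The compounds below may be only part of what the source reports. "The series", "measured", "known", "first", "only" and "open" are said of these compounds alone.

Working notes on a set sharing one core. Compound 1 `CC(C)c1ccc(NCC(=O)N[C@H]2CCOC2=O)cc1`, compound 2 `O=C(CNc1ccccc1)N[C@H]1CCOC1=O` and compound 3 `O=C(CNc1ccc(Br)cc1)N[C@H]1CCOC1=O` differ only at one aromatic carbon. In a functional assay on MCF7 cells (Homo sapiens) for antiproliferative activity, read by MTT assay, with a stated time of 72 h (a higher number here means a weaker inhibitor, a lower number a stronger inhibitor), compound 1 reaches only the limit > 64000 nM. In this assay compound 2 likewise reaches only the limit > 64000 nM. In this assay compound 3 gives > 64000 nM, which is a limit and not a number. Compound 3 thus stands where the whole set stands, at the limit of > 64000 nM in this assay, at which 3 of the 3 values shown sit. The steps a step that the two limits leave unreadable from compound 1 to compound 2, a step that the two limits leave unreadable from compound 1 to compound 3 and a step that the two limits leave unreadable from compound 2 to compound 3 cannot be sized, since each end is a limit. Compound 4 `O=C(CNc1ccc(F)cc1)N[C@H]1CCOC1=O` is not yet measured. Its change from compound 3 is fluoro in place of bromo on an aromatic carbon. The measured steps bear on it only in that none of the three groups tried at that carbon gave a readable value, so no direction can be read and a step in this assay beyond the scatter is not expected. The step from compound 3 to compound 4 is estimated as a step that the limit leaves unreadable from compound 3 to compound 4. Compound 4 is expected to give 100000 nM, within 30000 nM to 400000 nM.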

Compound 4, half-maximal inhibitory concentration: > 64000 nM
Compound 4 ended at the assay's limit; the forecaster's own chance of this, stated with the estimate: 85%; the middle value is on the limit's open side.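

The steps linking compound 4 to compound 1, compound 2 and compound 3 cannot be read, since each end is a limit and not a number: the limit of > 64000 nM in this assay, at which 4 of the 4 values shown sit.

The compounds shown leave open how far these four compounds lie apart in this assay, and whether any group at that aromatic carbon gives a readable value.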